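Triazole series, aryl hydrazone variant: nitro to fluoro

This account rests on a few compounds, and the source may have more. Where it says the series, first, only, none or still open, it means among the compounds named here.

Measured so far in a functional assay on HCT-116 cells (Homo sapiens) for inhibition, read by MTT assay, with a stated time of 48 h; on this read-out higher numbers stand for weaker inhibition and lower numbers for stronger inhibition:
compound 1, `Clc1ccccc1CSc1nnc(-c2ccncc2)n1-c1ccccc1`: 13900 nM
compound 2, `Fc1cccc(F)c1CSc1nnc(-c2ccncc2)n1-c1ccccc1`: 22100 nM
compound 3, `O=C(CSc1nnc(-c2ccncc2)n1-c1ccccc1)N/N=C/c1ccc([N+](=O)[O-])cc1`: 10200 nM

Compound 3 sits alongside compound 1, the two within the usual scatter, and apart from compound 2, that gap lying beyond it. Compound 4, `O=C(CSc1nnc(-c2ccncc2)n1-c1ccccc1)N/N=C/c1ccc(F)cc1`, differs from compound 3 by fluoro in place of nitro on an aromatic carbon. Within the data shown here, the only measured step, a 1.6-fold higher number from compound 1 to compound 2 (0.20 log units; within the scatter), swaps halogens on the other aryl group and stays within the scatter; nothing measured touches the aryl hydrazone end. No step beyond the scatter is therefore expected in this assay. For compound 4 the estimate is 12000 nM, range 5000 nM to 30000 nM, which is expected to mean a 1.2-fold higher number from compound 3 to compound 4 (0.07 log units; within the scatter).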

Compound 4, half-maximal inhibitory concentration: 7040 nM
Beside the measured number, compound 4's estimate is 1.7-fold (0.23 log units) above it; the range from low to high includes it.
By their numbers in this assay, from the lowest: compounds 4, 3, 1 and 2 (each within the scatter of the next, the first and the last beyond it).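

In this assay the aryl hydrazone end now has its first measured step: 4-fluorophenyl in place of 4-nitrophenyl gives a 1.4-fold lower number from compound 3 to compound 4 (0.16 log units; within the scatter) and so stays within the scatter. On this aromatic carbon, para to a large group, the nitro group with its 3 heavy atoms is therefore not needed to keep the number of compound 3, since a single fluoro serves as well. Nothing at hand explains why the two groups read alike.

The compounds shown leave open how an amine or a carboxylic acid on this same carbon would read. On these data alone, whether any group here can move the number beyond the scatter also stays open.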